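Swapping phenoxy for chloro on a 5-lipoxygenase inhibitor scaffold

The source may report more compounds than this note shows. Statements on the series, on what has been measured and on what is new or still open speak of the compounds shown alone.

Measured compounds:
- compound 1, `COc1ccc(/C=C2\SC(c3ccc(NC(=O)CCc4ccccc4)cc3)=NC2=O)cc1`: 260 nM
- compound 2, `COc1ccc(/C=C2\SC(c3ccc(Oc4ccccc4)cc3)=NC2=O)c2ccccc12`: 2150 nM
- compound 3, `O=C1N=C(c2ccc(Cl)cc2)S/C1=C\c1ccc(OCc2ccccc2)cc1`: 410 nM

All three were tested in an assay on cells for inhibition of Polyunsaturated fatty acid 5-lipoxygenase (Homo sapiens), read by HPLC, with stated times of 15 min and 10 min; a higher number here means a weaker inhibitor, a lower number a stronger inhibitor. Compound 2 gives the highest number of the three, so it is the weakest inhibitor here; compound 3 sits nearest to it, and compound 1 furthest away, with both gaps beyond the usual scatter of this kind of measurement. Compound 2 carries a phenoxy group on the phenyl ring attached to the shared core, para to a large group, and it is this group that is changed.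

The unmeasured compound 4, `COc1ccc(/C=C2\SC(c3ccc(Cl)cc3)=NC2=O)c2ccccc12`, keeps everything else of compound 2 and differs only by chloro in place of phenoxy on an aromatic carbon. Compound 3 shows that a chloro at this same position is compatible with a lower number in this assay than compound 2 reaches, though compound 3 also differs elsewhere, so no single change can be credited. On that basis a moderate drop in number, that is a stronger inhibitor, is the expected outcome, but a step within the scatter cannot be ruled out. The expected step is a 3.1-fold lower number from compound 2 to compound 4 (0.49 log units; beyond the scatter). Compound 4 is estimated at 700 nM, with a range from 250 nM to 2500 nM.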

Compound 4, half-maximal inhibitory concentration: 640 nM
Compound 4: middle estimate off by 1.1-fold (0.04 log units), on the high side; the range from low to high includes it.
By their numbers in this assay, from the lowest: compounds 1, 3 and 4 (each within the scatter of the next, the first and the last beyond it); then compound 2.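

In this assay, going by these compounds alone, exchanging phenoxy for chloro gives a 3.4-fold lower number from compound 2 to compound 4 (0.53 log units; beyond the scatter), and this is the only comparison here in which nothing else in the molecule changes. It shows that, on this scaffold, the phenoxy group with its whole aromatic ring and its oxygen is not needed for inhibition: a single chlorine atom on the same aromatic carbon gives a stronger inhibitor, not a weaker one. Nothing available explains why the number falls, so the step stands as an observation only.

The step cannot be divided among its parts, so the compounds shown do not tell whether the result comes from losing the phenoxy group or from gaining the chlorine; a bare hydrogen, a methyl or an amine at this same carbon would help separate the two. They also leave open whether chloro would beat phenoxy with another group on the far side of the shared core, such as the simple methoxyphenyl of compound 1, since no pair shown tests the swap there.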